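Dimethylamino for pyrrolidinyl on a phenylcyclohexane sigma ligand

The source may hold more compounds than are shown below. What is called first, only, known or untested is meant among the compounds shown, and "the series" means these compounds.

Three compounds share a saturated ring carrying a phenyl group and a basic side chain. Compound 1 `CN(C)CCC1CCCC(c2ccccc2)C1` gives 4.2 nM in an assay on membranes from brain for displacement of a labelled ligand from Sigma non-opioid intracellular receptor 1 (Cavia porcellus), read by scintillation counting, with a stated time of 120 min; on this read-out higher numbers stand for weaker inhibition and lower numbers for stronger inhibition. Compound 2 `c1ccc([C@H]2CCC[C@@H](CCN3CCCC3)C2)cc1` gives 3.6 nM, the lowest of the three numbers, though compound 1 sits within the scatter of it. Compound 3 `NCC[C@H]1CCC[C@H](c2ccccc2)C1`, with a free amine, gives 603 nM.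

Compound 4 `CN(C)CC[C@@H]1CCC[C@H](c2ccccc2)C1` differs from compound 2 by dimethylamino in place of pyrrolidin-1-yl on a saturated chain carbon, two bonds along the chain from a saturated ring carbon. Compound 1 carries this same dimethylamino group and gives 4.2 nM, so no step beyond the scatter is expected from compound 2 to compound 4. Compound 4 is estimated at 4.5 nM, within 1.5 nM to 14 nM, a step of a 1.3-fold higher number from compound 2 to compound 4 (0.10 log units; within the scatter) that is expected.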

Compound 4, inhibition constant: 14 nM
Compound 4: middle estimate off by 3.1-fold (0.49 log units), on the low side; measured number inside the range.
By their numbers in this assay, from the lowest: compounds 2 and 1 (each within the scatter of the next); then compound 4; then compound 3.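

In this assay, dimethylamino in place of pyrrolidin-1-yl on this saturated chain carbon gives a 3.9-fold higher number from compound 2 to compound 4 (0.59 log units; beyond the scatter) and so is not a silent swap. The same atoms and bonds also give a 3.3-fold higher number from compound 1 to compound 4 (0.52 log units; beyond the scatter) and so the dimethylamino group alone does not fix the number. This second step involves no change of group, and what can be said of it rests on one point: the fact that one of compounds 1 and 4 is drawn with a defined configuration and the other without, at the place where they differ

On these data alone, whether piperidin-1-yl or diethylamino on the same chain would follow pyrrolidin-1-yl or dimethylamino stays open. As far as these compounds go, the values of the other stereoisomers of compound 4 also remain open.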